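Halogen swap on an enone core in a growth inhibition assay

The source may report more compounds than this note shows. Statements on the series, on what has been measured and on what is new or still open speak of the compounds shown alone.

Measured compounds:
compound 1, `CC(=O)OC/C(=C\c1ccc(Cl)cc1)C(=O)c1ccccc1`: 3200 nM
compound 2, `CC(=O)OC/C(=C\c1ccc(F)cc1)C(=O)c1ccccc1`: 25000 nM
compound 3, `C=C(C/C(=C\c1ccc(Cl)cc1)C(=O)c1ccccc1)C(=O)c1ccccc1`: 22000 nM

In a functional assay on HeLa cells (Homo sapiens) for inhibition, read by sulforhodamine B assay, with a stated time of 48 h (a lower number here means a stronger inhibitor of growth, a higher number a weaker inhibitor of growth), compound 1 gives 3200 nM. Compound 2 carries fluoro in place of chloro on an aromatic carbon, and the step of a 7.8-fold higher number from compound 1 to compound 2 (0.89 log units; beyond the scatter) was recorded. Compound 3, a larger molecule built on a different core, gives 22000 nM in this assay; how its core differs from that of compound 1 is not broken down here. Its value and that of compound 2 lie within the scatter of each other, so nothing is said about their order.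

Compound 4, `C=C(C/C(=C\c1ccc(F)cc1)C(=O)c1ccccc1)C(=O)c1ccccc1`, is not yet measured. It differs from compound 3 by fluoro in place of chloro on an aromatic carbon, the same change that separates compound 2 from compound 1, made at the same place. Going by the values given here, since only one earlier step of this kind is known, the expectation rests on it alone. Compound 4 is expected to show a 5.5-fold higher number from compound 3 to compound 4 (0.74 log units; beyond the scatter), resting on the step of a 7.8-fold higher number from compound 1 to compound 2 (0.89 log units; beyond the scatter) measured on the other core. Compound 4 is thus estimated at 120000 nM, with a range from 35000 nM to 400000 nM, and a real chance that this assay reports only a limit.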

Compound 4, concentration for 50% growth inhibition: 18000 nM
Compound 4: middle estimate off by 6.7-fold (0.82 log units), on the high side, outside the stated range (below it).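

On the core of compound 3, fluoro in place of chloro on an aromatic carbon leaves no readable difference in this assay, with a 1.2-fold lower number from compound 3 to compound 4 (0.09 log units; within the scatter). The same change gave a clear step on the core of compound 1, so the two results do not agree: the same change on two cores in this assay, a 7.8-fold higher number (0.89 log units; beyond the scatter) from compound 1 to compound 2 and a 1.2-fold lower number (0.09 log units; within the scatter) from compound 3 to compound 4, 9.5-fold (0.98 log units) apart, beyond the scatter of two such steps

This shows that, in these four compounds, the step measured on one core did not carry over to the other, so a step from one core cannot be assumed to hold on the other in this series. Going by these compounds alone, with only one pair on each core, it does not show which part of the cores goes with the difference, nor how the change would behave on any further core.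

From the compounds shown here alone, it remains open whether a bromo, a methoxy or an amine in the same place on the ring would give a clear step on the core of compound 1 and none on the core of compound 3. Also open, going by these compounds, is whether replacing the acetate ester of compound 1 with another ester or an amide would keep the step seen there.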